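The compounds below may be only part of what the source reports. "The series", "measured", "known", "first", "only" and "open" are said of these compounds alone.

This piece follows one change made to compound 1, whose structure is `O=c1[nH]cnc2c1c(-c1cccs1)cn2[C@@H]1O[C@H](CO)[C@@H](O)[C@H]1O`. The measurement used throughout is a functional assay on A549 cells (Homo sapiens), read by MTT assay, with a stated time of 72 h; on this read-out higher numbers stand for weaker inhibition and lower numbers for stronger inhibition. In this assay compound 1 gives > 20000 nM, which is a limit of the assay rather than a number. Two other compounds share the same core and sugar. Compound 2, with the structure `Cc1nc(N)c2c(-c3ccco3)cn([C@@H]3O[C@H](CO)[C@@H](O)[C@H]3O)c2n1`, also reaches only a limit in this assay, > 20000 nM. For the measured compounds named here, compound 3, with the structure `COc1ncnc2c1c(-c1cccs1)cn2[C@@H]1O[C@H](CO)[C@@H](O)[C@H]1O`, gives 4850 nM in this assay, the single true number among the three. Going by the values given here, compound 1 therefore stands at the limit of > 20000 nM in this assay, at which 2 of the 3 values shown sit, and no pair of measured compounds differs in a single place, so no measured step is available to lean on.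

The change leads to compound 4, whose structure is `O=c1[nH]cnc2c1c(-c1ccco1)cn2[C@@H]1O[C@H](CO)[C@@H](O)[C@H]1O`. Its difference from compound 1 is furan-2-yl in place of thiophen-2-yl on an aromatic carbon. The two groups that are exchanged are alike in size and shape, and nothing in the measured set shows either one favoured over the other. Because compound 1 sits at a limit, > 20000 nM, only a large gain could move compound 4 into the measured range, and such a gain is not expected. I expect the step that the limit leaves unreadable from compound 1 to compound 4 to be none beyond the scatter. Compound 4 is accordingly estimated at 30000 nM, with a range from 10000 nM to 100000 nM, most likely reported again only as a limit.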

Compound 4, half-maximal inhibitory concentration: > 20000 nM
Compound 4 ended at the assay's limit; the forecaster's own chance of this, stated with the estimate: 75%; the middle value lies beyond the limit too.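

For the compounds shown here, compound 1 and compound 4 both reach only a limit in this assay, so no step between them can be read. The compounds shown leave open whether furan-2-yl and thiophen-2-yl differ at all in this assay, and how far either compound actually lies from the measured range.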